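The source may hold more compounds than are shown below. What is called first, only, known or untested is meant among the compounds shown, and "the series" means these compounds.

Compound 1 `Cc1ccc(NC(=O)c2cc3ccccc3oc2=O)cc1` is the starting point of this small set. In an in vitro assay on BTI-TN-5B1-4 cells for inhibition of Amine oxidase [flavin-containing] B (Homo sapiens), read by fluorescence (a lower number here means a stronger inhibitor, a higher number a weaker inhibitor), compound 1 gives 710 nM. Compound 2 `Cc1ccc(NC(=O)c2cc3ccccc3oc2=O)c(C)c1` carries one extra group; in this assay compound 2 gives 13700 nM. The change is methyl in place of hydrogen on an aromatic carbon, and it made the step of a 19-fold higher number from compound 1 to compound 2 (1.29 log units; beyond the scatter).

Compound 3 `COc1ccc(NC(=O)c2cc3ccc(OCc4ccccc4)cc3oc2=O)cc1OC` is built on a different core; how the two cores differ is not broken down here. In this assay compound 3 gives 4390 nM.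

Compound 4 `COc1ccc(NC(=O)c2cc3ccc(OCc4ccccc4)c(C)c3oc2=O)cc1OC` differs from compound 3 by methyl in place of hydrogen on an aromatic carbon. Within the data shown here, it is the same kind of change as the one from compound 1 to compound 2, but the surroundings differ: in compound 2 the methyl sits ortho to a large group and meta to a methyl group, whereas in compound 4 it sits on a fused ring system, ortho to a benzyloxy group, ortho to a fused ring and meta to a fused ring. Because the step of a 19-fold higher number from compound 1 to compound 2 (1.29 log units; beyond the scatter) was large, a weaker result for compound 4 is expected, though with the place differing, a smaller step of a 2.7-fold higher number from compound 3 to compound 4 (0.44 log units; beyond the scatter) is estimated. Compound 4 is estimated to give 12000 nM, between 3000 nM and 50000 nM.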

Compound 4, half-maximal inhibitory concentration: 4980 nM
Compound 4: middle estimate off by 2.4-fold (0.38 log units), on the high side; low and high end bracket the measured number.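

In this assay, the added methyl gives a 1.1-fold higher number from compound 3 to compound 4 (0.05 log units; within the scatter), so compound 3 and compound 4 cannot be told apart here. The same swap of hydrogen for methyl therefore does not carry the same size of step from one core to the other: the same change on two cores in this assay, a 19-fold higher number (1.29 log units; beyond the scatter) from compound 1 to compound 2 and a 1.1-fold higher number (0.05 log units; within the scatter) from compound 3 to compound 4, 17-fold (1.23 log units) apart, beyond the scatter of two such steps. This shows that the large step seen on the core of compound 1 cannot be assumed on the core of compound 3, but it does not show why, as the methyl sits in a different place in each pair and the surrounding groups also differ, and these compounds cannot separate those factors.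

As far as these compounds go, it remains open how a methyl would behave on the core of compound 1 in the place it takes in compound 4, a comparison that would help to separate place from core. From the compounds shown here alone, it is also open whether a fluorine atom or an amine in that same place would give a step like that of methyl.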